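The source may report more compounds than this note shows. Statements on the series, on what has been measured and on what is new or still open speak of the compounds shown alone.

Working notes on the series in an assay on isolated protein (Bos taurus) for inhibition of geranylgeranyl transferase type-1 subunit beta (Homo sapiens); on this read-out higher numbers stand for weaker inhibition and lower numbers for stronger inhibition. Compound 1 `Cn1cncc1C(OCc1ccc(C#N)c(-c2ccc(Cl)c(Cl)c2)n1)c1ccc(C#N)cc1` gives 1600 nM. For compound 2 `Cn1cncc1C(OCc1ccc(C#N)nc1-c1ccccc1)c1ccc(C#N)cc1` only a limit of the assay is known, reported as > 10 nM; this is the single entry sitting at the limit of > 10 nM in this assay, at which 1 of the 2 values shown sits. Compound 3 `Cn1cncc1C(OCc1ccc(C#N)nc1-c1cc(Cl)cc(Cl)c1)c1ccc(C#N)cc1` is drawn from compound 2 by 3,5-dichlorophenyl in place of phenyl on an aromatic carbon. Among the compounds with values here, no measured pair covers this change, so its effect in this assay cannot be read from the data; compound 1, carrying a different dichlorophenyl, is only a loose anchor. Compound 3 is expected near 300 nM, within 30 nM to 3000 nM. The implied step that the limit leaves unreadable from compound 2 to compound 3 is an estimate, and any direction beyond the scatter is uncertain.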

Compound 3, half-maximal inhibitory concentration: 1400 nM
Compound 3: the middle estimate sits 4.7-fold (0.67 log units) below what was measured; the measured number falls inside the stated range.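

Within the data shown here, no step from compound 2 to compound 3 can be read in this assay, because compound 2 carries only a limit: the limit of > 10 nM in this assay, at which 1 of the 3 values shown sits. The compounds shown leave open how 3,5-dichlorophenyl in place of phenyl changes inhibition in this assay.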